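A few compounds are considered here, and "the series" means these few. Any claim that something is new, unique, unknown or untested is made for them only; others in the source may bear on it.

Compound 1, `CCCn1c(=O)[nH]c2nc(-c3ccc(S(=O)(=O)N4CCN(c5ccc(Cl)cc5F)CC4)cc3)[nH]c2c1=O`: 9%
Compound 2, `CCCn1c(=O)[nH]c2nc(-c3ccc(S(=O)(=O)N4CCN(c5cccc(Cl)c5)CC4)cc3)[nH]c2c1=O`: 21%
Compound 3, `CCCn1c(=O)[nH]c2nc(-c3ccc(S(=O)(=O)N4CCN(c5ccccc5Br)CC4)cc3)[nH]c2c1=O`: 28%

These three values come from an assay on CHO cells for displacement of a labelled ligand from adenosine receptor A1 (Homo sapiens), read by scintillation counting, with a stated time of 90 min, tested at 1 uM, in the presence of a further agent that is not named here; a lower number here means less inhibition, a higher number more inhibition at the concentration tested (going by the name of the read-out). Compound 3 holds the highest of the three numbers; its gap to compound 2 lies within the scatter, so those two cannot be ranked against each other, while its gap to compound 1 lies beyond it. The three compounds share one core and differ only in the aryl group on the amine nitrogen in the ring. Two steps are beyond the scatter: a number 12 percentage points higher from compound 1 to compound 2 (beyond the scatter) and a number 19 percentage points higher from compound 1 to compound 3 (beyond the scatter), both leading away from 4-chloro-2-fluorophenyl. The step of a number 7 percentage points higher from compound 2 to compound 3 (within the scatter), which exchanges one halogen-bearing phenyl for another, stays within the scatter.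

Compound 4, `CCCn1c(=O)[nH]c2nc(-c3ccc(S(=O)(=O)N4CCN(c5cccc(Br)c5)CC4)cc3)[nH]c2c1=O`, is not yet measured. It differs from compound 3 in one place: 3-bromophenyl in place of 2-bromophenyl on an amine nitrogen in a ring. For the measured compounds named here, of the measured steps, the one from compound 2 to compound 3 bears most closely on this change, since it also swaps one halogen-bearing phenyl for another, and it stayed within the scatter; the two larger steps both start from compound 1, whose aryl group plays no part here. Compound 4 is therefore expected to sit close to compound 3 in this assay, with an expected step of a number 5 percentage points lower from compound 3 to compound 4 (within the scatter) that does not exceed the scatter. The estimate for compound 4 in this assay is 23%, within a range from 8% to 38%.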

Compound 4, a percentage reported as inhibition, at one concentration (the size of the read-out at that concentration, not a potency): -1%
For compound 4 the middle estimate is 24 percentage points above the measured one; measured number outside the range, below it.
By their numbers in this assay, from the lowest: compounds 4 and 1 (each within the scatter of the next); then compounds 2 and 3 (each within the scatter of the next).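

Exchanging 2-bromophenyl for 3-bromophenyl gains or loses no atom, yet it gives a number 29 percentage points lower from compound 3 to compound 4 (beyond the scatter) in this assay, so in this set the place of the bromine on the phenyl ring matters as well as its presence. Bromo in place of chloro on the aromatic carbon gives a number 22 percentage points lower from compound 2 to compound 4 (beyond the scatter) as well, and this is the first change of the halogen alone; the earlier step between compound 2 and compound 3 changed both the halogen and its place, and its result within the scatter had hidden how much each single change can matter. The step of a number 10 percentage points lower from compound 1 to compound 4 (within the scatter) adds that two quite different aryl groups can give results that cannot be told apart, so a similar number here says little about how similar the groups are.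

These three comparisons cannot show how an unsubstituted phenyl, or a phenyl carrying a methoxy group or an amine in place of the halogen, would behave at this position. Why such small changes shift the number remains unexplained, as no supporting measurement bears on these steps.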